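The source may report more compounds than this note shows. Statements on the series, on what has been measured and on what is new or still open speak of the compounds shown alone.

Compound 2 `CC(C)Cn1nnc2c(Br)cccc21` holds the lower of the two numbers recorded so far in an ADME assay on microsomes from liver (Homo sapiens) for metabolic stability, tested at 2.5 uM; a higher number here means faster removal of the compound, a lower number slower removal; in that setting compound 2 gives 4.2 mL/min/g. Within the data shown here, its only measured neighbour is compound 1 `Brc1cccc2c1nnn2CC1CCC1`, which in this assay gives 8.7 mL/min/g. Among the measured compounds shown here, the single known step, a 2.1-fold lower number from compound 1 to compound 2 (0.32 log units; beyond the scatter), comes from isopropyl in place of cyclobutyl on a saturated chain carbon bound to an aromatic nitrogen.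

Compound 3 `CCCCn1nnc2c(Br)cccc21` has not yet been measured. It differs from compound 2 as propyl in place of isopropyl on a saturated chain carbon bound to an aromatic nitrogen. For the measured compounds named here, no measured step exchanges isopropyl for propyl at this place, so the step from compound 1 to compound 2 is the only guide, and it shows that swapping one small saturated group for another on this carbon shifted the number by a modest amount. A step of comparable size or smaller, in either direction, is therefore expected here, with the value most likely staying near that of compound 2.

For compound 3 the expected result is 5.5 mL/min/g, with a likely range from 2.5 mL/min/g to 12 mL/min/g, which corresponds to an expected step of a 1.3-fold higher number from compound 2 to compound 3 (0.12 log units; within the scatter).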

Compound 3, intrinsic clearance in a liver preparation (reported as CLH), per the amount of preparation that the assay uses: 9.5 mL/min/g
The estimate for compound 3 lay 1.7-fold (0.24 log units) below the measured number, within the range that was stated.
By their numbers in this assay, from the lowest: compound 2; then compounds 1 and 3 (each within the scatter of the next).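

The change from isopropyl to propyl keeps the same atoms and only joins them differently, yet in this assay it gives a 2.3-fold higher number from compound 2 to compound 3 (0.35 log units; beyond the scatter) and so shows that the arrangement of the chain at this place can shift the number, even with its composition unchanged. Propyl in place of cyclobutyl gives a 1.1-fold higher number from compound 1 to compound 3 (0.04 log units; within the scatter) and leaves the open chain and the ring at a similar level, so among these three compounds only compound 2, with isopropyl, stands apart, with a lower number than both of the others. Nothing available here explains why isopropyl differs from the other two groups.

The compounds shown leave open how a longer chain such as pentyl, or a chain carrying an amine or a hydroxyl group, would read on this saturated chain carbon bound to an aromatic nitrogen. They also leave open whether isopropyl would stand apart from propyl in the same way on a different core, since this single comparison rests on one shared core.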